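The source may hold more compounds than are shown below. What is called first, only, known or untested is meant among the compounds shown, and "the series" means these compounds.

Compound 1 `COc1ncc(C(=O)NC2(C(=O)N[C@H](C)c3ccc(-n4nc(Cl)c5ccccc54)cc3F)CC2)s1`: 8.3 h in an in vivo ADME assay on the whole organism (strain Mongrel) for metabolic stability, with Canis familiaris (Canis lupus familiaris) as the target; a lower number here means that the compound disappears faster, a higher number that the compound lasts longer
Compound 2 `COc1cncc(C(=O)NC2(C(=O)N[C@H](C)c3ccc(-n4nc(Cl)c5ccccc54)cc3F)CC2)c1`: 2.3 h
Compound 3 `Cc1cncc(C(=O)NC2(C(=O)N[C@H](C)c3ccc(-n4nc(Cl)c5ccccc54)cc3F)CC2)c1`: 2.6 h

Among these three numbers compound 3 stands second highest; its value and that of compound 2 lie within the scatter of each other, while compound 1 sits a clear step above, as a 3.2-fold lower number from compound 1 to compound 3 (0.50 log units; beyond the scatter) shows. Compound 4 `Cc1nnsc1C(=O)NC1(C(=O)N[C@H](C)c2ccc(-n3nc(Cl)c4ccccc43)cc2F)CC1` carries 4-methyl-1,2,3-thiadiazol-5-yl in place of 5-methylpyridin-3-yl on a carbonyl carbon. Among the measured compounds shown here, the steps that bear on this are a 3.6-fold lower number from compound 1 to compound 2 (0.56 log units; beyond the scatter) and a 3.2-fold lower number from compound 1 to compound 3 (0.50 log units; beyond the scatter), in which a five-membered aromatic ring with hetero atoms on the carbonyl carbon gave way to a six-membered ring and the number fell. Compound 4 reverses that direction, returning to a five-membered ring, though a different one, so a modest rise is expected rather than a confident return to the level of compound 1. The estimate for compound 4 is 4.5 h (1.8 h to 11 h), meaning a 1.7-fold higher number from compound 3 to compound 4 (0.24 log units; within the scatter) is expected.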

Compound 4, half-life: 2.4 h
Estimate against measurement, compound 4: 1.9-fold (0.27 log units) above, and the stated range covers the measured number.
By their numbers in this assay, from the lowest: compounds 2, 4 and 3 (each within the scatter of the next); then compound 1.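

In this assay, a five-membered ring on the carbonyl carbon does not by itself keep the number high: with a 1.1-fold lower number from compound 3 to compound 4 (0.03 log units; within the scatter) and a 1.0-fold higher number from compound 2 to compound 4 (0.02 log units; within the scatter), the 4-methyl-1,2,3-thiadiazol-5-yl group sits level with both pyridines, whereas a 3.5-fold lower number from compound 1 to compound 4 (0.54 log units; beyond the scatter) leaves it clearly short of the 2-methoxy-1,3-thiazol-5-yl group. Ring size alone therefore does not separate these four compounds, and only compound 1 stands apart. Nothing measured here explains this difference. Still open, from the compounds shown here alone, is whether the level of compound 1 comes from its ring or its methoxy group, and how a 2-amino-1,3-thiazol-5-yl or a plain phenyl on the same carbonyl carbon would compare.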